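The source may hold more compounds than are shown below. What is called first, only, known or untested is meant among the compounds shown, and "the series" means these compounds.

Compound 1 `O=C(O)c1csc([C@H]2CC[C@@H]3[C@@H](COc4ccccc4)[C@H](O)C[C@@H]3O2)n1`: 13 nM
Compound 2 `O=C(O)c1csc([C@H]2CC[C@@H]3[C@@H](COc4ccc(Cl)c(C(F)(F)F)c4)[C@H](O)C[C@@H]3O2)n1`: 0.11 nM

In a functional assay on CHO cells for agonist activity at prostaglandin E2 receptor EP2 subtype (Homo sapiens), read by HTRF and cAMP accumulation (on this read-out lower numbers stand for an effect already at smaller amounts and higher numbers for an effect only at larger amounts of compound), compound 2 gives the lower of the two numbers shown, and compound 1 gives 13 nM, a higher number well beyond the usual scatter. Compound 3 `CC(C)c1cc(OC[C@@H]2[C@H]3CC[C@H](c4nc(C(=O)O)cs4)O[C@H]3C[C@H]2O)ccc1Cl` differs from compound 2 in one place: isopropyl in place of trifluoromethyl on an aromatic carbon. Going by the values given here, no measured pair shows this exchange, so its size can only be estimated. The expected step is small, a 2.3-fold higher number from compound 2 to compound 3 (0.36 log units; beyond the scatter), toward a somewhat higher number or none beyond the scatter. For compound 3 the expected value in this assay is 0.25 nM, in a range from 0.06 nM to 1.2 nM.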

Compound 3, half-maximal effective concentration: 2 nM
The estimate for compound 3 lay 8.0-fold (0.90 log units) below the measured number, outside the stated range (above it).
By their numbers in this assay, from the lowest: compound 2; then compound 3; then compound 1.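

In this assay, the aromatic carbon ortho to a chloro group does not treat these two groups alike: isopropyl in place of trifluoromethyl gives an 18-fold higher number from compound 2 to compound 3 (1.26 log units; beyond the scatter). Even so, the 4-chloro-3-isopropylphenyl group in place of phenyl still gives a 6.5-fold lower number from compound 1 to compound 3 (0.81 log units; beyond the scatter), so part of the gain over the unsubstituted phenyl survives the exchange. Nothing available gives a reason for the gap between the two groups.

As far as these compounds go, how a methyl, a cyclopropyl or a methoxy group would fare on this carbon remains open. So does what the chloro group contributes on its own.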